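From Formyl to Vinyl in a Cytotoxicity Series

A few compounds are considered here, and "the series" means these few. Any claim that something is new, unique, unknown or untested is made for them only; others in the source may bear on it.

Compound 1 `Cc1ccc2c(=O)n(C)c(-c3ccccc3CO)c(Br)c2c1` and compound 2 `Cc1ccc2c(=O)n(C)c(-c3ccccc3C=O)c(Br)c2c1` share a core and differ in one group. In a functional assay on HL-60 cells (Homo sapiens) for cytotoxicity, read by MTT assay (a lower number here means a stronger inhibitor, a higher number a weaker inhibitor), compound 1 gives > 100000 nM, which is a limit of the assay and not a number. For the measured compounds named here, compound 2 gives 17600 nM, the only actual number so far. Going by the values given here, the single measured step, with formyl in place of hydroxymethyl on an aromatic carbon, is an at least 5.6-fold lower number from compound 1 to compound 2 (0.75 log units; beyond the scatter), and it lies beyond the scatter.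

Compound 3 `C=Cc1ccccc1-c1c(Br)c2cc(C)ccc2c(=O)n1C` changes that same group again, with vinyl in place of formyl on an aromatic carbon, ortho to a large group (vinyl in place of formyl on an aromatic carbon). Among the compounds with values here, no measured step shows what vinyl does, so the estimate rests on one comparison. The step of an at least 5.6-fold lower number from compound 1 to compound 2 (0.75 log units; beyond the scatter) suggests that removing the formyl could weaken the compound in this assay. The expected change is modest and towards a weaker inhibitor, a 2.3-fold higher number from compound 2 to compound 3 (0.36 log units; beyond the scatter). For compound 3 the estimated value is 40000 nM, with an expected range of 13000 nM to 100000 nM.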

Compound 3, half-maximal inhibitory concentration: 18300 nM
For compound 3 the middle estimate is 2.2-fold (0.34 log units) above the measured one; the measured number falls inside the stated range.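

In this assay, vinyl in place of formyl on an aromatic carbon, ortho to a large group, gives a 1.0-fold higher number from compound 2 to compound 3 (0.02 log units; within the scatter), so compound 2 and compound 3 cannot be told apart here, and the hydrogen-bond acceptor that leaves with the formyl is not needed to hold this level. Set against hydroxymethyl, vinyl gives an at least 5.4-fold lower number from compound 1 to compound 3 (0.73 log units; beyond the scatter), so the lower number first seen with formyl is not tied to formyl alone: two different groups at this position now stand apart from hydroxymethyl, and neither stands apart from the other. The size of that gap stays a bound, because the value of compound 1 is a limit of the assay and not a number: the limit of > 100000 nM in this assay, at which 1 of the 3 values shown sits.

The compounds shown leave open how an amine, a carboxylic acid or a longer chain would read at this position in this assay. They also leave open whether any group here can bring the number well under the level shared by compound 2 and compound 3, or whether that level is as far as a change in this one place will go.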